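Replacing the Acid Hydrogen with a Methoxyphenethyl Ester

The source may report more compounds than this note shows. Statements on the series, on what has been measured and on what is new or still open speak of the compounds shown alone.

Compound 1 `C/C=C1/[C@H](O[C@@H]2O[C@H](CO)[C@@H](O)[C@H](O)[C@H]2O)OC=C(C(=O)OC)[C@H]1CC(=O)O` is one of two compounds already tested. In a functional assay on SK-BR-3 cells (Homo sapiens) for antiproliferative activity, read by MTT assay, with a stated time of 72 h (a lower number here means a stronger inhibitor, a higher number a weaker inhibitor), compound 1 gives > 15000 nM, which is a limit of the assay rather than a measured number. Compound 2 `C/C=C1/[C@H](O[C@@H]2O[C@H](COC(C)=O)[C@@H](OC(C)=O)[C@H](OC(C)=O)[C@H]2OC(C)=O)OC=C(C(=O)OC)[C@H]1CC(=O)O` is the other one. In this assay compound 2 gives > 15000 nM, again a limit of the assay. Both results therefore sit together at the same boundary, (the limit of > 15000 nM in this assay, at which 2 of the 2 values shown sit), and nothing can be said about any difference between compound 1 and compound 2; compound 1 stands at the weak end of what this assay can report, with no numbered value of its own.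

Compound 3 `C/C=C1/[C@H](O[C@@H]2O[C@H](CO)[C@@H](O)[C@H](O)[C@H]2O)OC=C(C(=O)OC)[C@H]1CC(=O)OCCc1ccc(OC)cc1` has not yet been measured. It differs from compound 1 by 2-(4-methoxyphenyl)ethyl in place of hydrogen on an oxygen next to a carbonyl group. Within the data shown here, no step between measured compounds exists here to guide the expectation, so the forecast rests on the change itself. The step from compound 1 to compound 3 is expected to be an at least 1.5-fold lower number from compound 1 to compound 3 (0.17 log units; that floor lies within the scatter), a modest move toward stronger inhibition rather than none beyond the scatter. Compound 3 is estimated at about 10000 nM, within a range from 3000 nM to 30000 nM, and a result that is again only a limit remains quite possible.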

Compound 3, half-maximal inhibitory concentration: > 20000 nM
Compound 3 ended at the assay's limit; the forecaster's own chance of this, stated with the estimate: 50%; at least 2.0-fold (0.30 log units) between middle value and limit.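

In this assay compound 3 gives > 20000 nM, which is a limit of the assay and not a number. Compound 1 also has only a limit, so the step between compound 1 and compound 3 cannot be read. The compounds shown leave open whether 2-(4-methoxyphenyl)ethyl in place of hydrogen changes the antiproliferative activity at all.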